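The source may report more compounds than this note shows. Statements on the series, on what has been measured and on what is new or still open speak of the compounds shown alone.

Of the compounds shown here, three built on a shared core have been tested in a physicochemical assay for solubility; on this read-out higher numbers stand for higher solubility and lower numbers for lower solubility. Compound 1 `COc1cc2c(cc1OC)[C@@H](C)C(=O)N(C)C=C2` gives >= 139 ug/mL, which is a limit of the assay. Compound 2 `CC1C(=O)N(C)C=Cc2cc(OCC(C)(C)O)ccc21` gives >= 131 ug/mL, also a limit. Compound 3 `C[C@H]1C(=O)N(C)C=Cc2cc(OC(CO)CO)ccc21` gives >= 142 ug/mL, again a limit. All three values shown are limits, so compound 3 cannot be ranked against the other two. Compound 4 `C[C@H]1C(=O)N(C)C=Cc2cc(CCO)ccc21` carries 2-hydroxyethyl in place of 2-hydroxy-1-(hydroxymethyl)ethoxy on an aromatic carbon. Within the data shown here, no measured pair shows what such a change does in this assay, so no shift beyond the scatter, in either direction, is expected. The expected change is small, an at least 1.0-fold lower number from compound 3 to compound 4 (0.02 log units; that floor lies within the scatter). For compound 4 the estimate is 135 ug/mL, with an expected range of 85 ug/mL to 175 ug/mL.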

Compound 4, solubility: >= 108 ug/mL
Compound 4: no number, only a limit; the forecaster's own chance of this, stated with the estimate: 70%; the middle value is on the limit's open side.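

Among these compounds, compound 3 and compound 4 each give only a limit in this assay, so no step between them can be read. The compounds shown leave open what swapping 2-hydroxy-1-(hydroxymethyl)ethoxy for 2-hydroxyethyl does to this read-out.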